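Swapping a fluorinated phenyl for a fused bicyclic ketone

The source may report more compounds than this note shows. Statements on the series, on what has been measured and on what is new or still open speak of the compounds shown alone.

Two compounds share an amide-linked core and differ only in the group on an oxygen on a saturated carbon. Compound 1 `CN(C)c1ccc(C(=O)Nc2cccc(NC(=O)COc3ccc4c(c3)NC(=O)CC4)c2)cc1` reaches only the limit of an assay on isolated protein for inhibition of Rho-associated protein kinase 1 (Homo sapiens), read by scintillation counting, radiometric assay and 33P incorporation, with a stated time of 40 min, in the presence of a further agent that is not named here (a higher number here means a weaker inhibitor, a lower number a stronger inhibitor), giving > 10000 nM, which is a limit and not a number. Among the compounds with values here, compound 2 `COc1ccc(OCC(=O)Nc2cccc(NC(=O)c3ccc(N(C)C)cc3)c2)cc1F` gives 1820 nM, the only actual number available here, so it stands alone among the measured values. The change from compound 1 to compound 2 brought an at least 5.4-fold lower number from compound 1 to compound 2 (0.73 log units; beyond the scatter), which is read against (the limit of > 10000 nM in this assay, at which 1 of the 2 values shown sits).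

Compound 3 `CN(C)c1ccc(C(=O)Nc2cccc(NC(=O)COc3ccc4c(c3)OCCC4=O)c2)cc1` carries a group of 11 heavy atoms (9 carbon, 2 oxygen; one six-membered non-aromatic ring with 1 hetero atom, one six-membered aromatic ring of carbon only) in place of a group of 9 heavy atoms (7 carbon, 1 oxygen, 1 fluorine; one six-membered aromatic ring of carbon only), on an oxygen on a saturated carbon. Within the data shown here, this moves in the opposite sense to the one measured step: it again puts a fused two-ring group, with a six-membered non-aromatic ring holding one hetero atom, in place of the small fluorinated aromatic ring. Among the measured compounds shown here, since the only step available in this assay shows the smaller group gaining at least modestly, compound 3 is expected to lose ground, and the step is estimated as a 4.4-fold higher number from compound 2 to compound 3 (0.64 log units; beyond the scatter). Compound 3 is therefore estimated at 8000 nM, within a range from 2500 nM to 30000 nM, with a fair chance that only a limit is reported.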

Compound 3, half-maximal inhibitory concentration: 144 nM
Compound 3: middle estimate off by 56-fold (1.74 log units), on the high side; the measured number lies below the stated range.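

Compound 3 shows that a fused two-ring group on this oxygen is not a penalty in itself, since replacing the 3-fluoro-4-methoxyphenyl gives a 13-fold lower number from compound 2 to compound 3 (1.10 log units; beyond the scatter) in this assay, so the earlier gain of compound 2 over compound 1 does not mean that smaller is better here. Compound 1 and compound 3 both carry a group of 11 heavy atoms with the same ring types, one with 9 carbon, 1 nitrogen, 1 oxygen and the other with 9 carbon, 2 oxygen, yet the change gives an at least 69-fold lower number from compound 1 to compound 3 (1.84 log units; beyond the scatter), so the atoms of the fused group matter far more than its size or ring count. The value of compound 1, > 10000 nM, is a limit and not a number, so the true size of that step stays unknown: the limit of > 10000 nM in this assay, at which 1 of the 3 values shown sits.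

The compounds shown do not separate the contribution of the carbonyl from that of the oxygen within the non-aromatic ring of compound 3. Going by these compounds, it also remains open how this position would respond to a fused group carrying an amine or a carboxylic acid, or to an unsubstituted phenyl.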